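From 3-Chlorophenyl to 4-Chlorophenyl in Compound 2

The compounds below may be only part of what the source reports. "The series", "measured", "known", "first", "only" and "open" are said of these compounds alone.

In a functional assay on HepG2 cells (Homo sapiens) for antiproliferative activity, read by MTT assay, with a stated time of 72 h (on this read-out lower numbers stand for stronger inhibition and higher numbers for weaker inhibition), compound 2 (`NC1=NC2(CCSCC2)N(OCCCOc2cccc(Cl)c2)C(N)=N1`) gives 90 nM as the lowest of the two numbers available. Compound 3 (`NC1=NC2(CCOCC2)N(OCCCOc2ccccc2Cl)C(N)=N1`) stands higher at 1750 nM by a margin beyond the scatter. Compound 1 (`NC1=NC2(CCOCC2)N(OCCCOc2ccccc2)C(N)=N1`) has the entry "not determined" (no result reported) and so offers no comparison. Compound 4 (`NC1=NC2(CCSCC2)N(OCCCOc2ccc(Cl)cc2)C(N)=N1`) is still to be measured and carries 4-chlorophenyl in place of 3-chlorophenyl on an oxygen on a saturated carbon with the rest of compound 2 unchanged. Among the compounds with values here, no measured pair shows this change alone, so the expectation rests on compound 2 at 90 nM and no shift beyond the scatter is expected in this assay in either direction. The expected step (a 1.3-fold higher number from compound 2 to compound 4 (0.12 log units; within the scatter)) is correspondingly small. For compound 4 the estimated value is 120 nM with an expected range from 35 nM to 450 nM around it.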

Compound 4, half-maximal inhibitory concentration: 1100 nM
The estimate for compound 4 lay 9.2-fold (0.96 log units) below the measured number, outside the stated range (above it).
By their numbers in this assay, from the lowest: compound 2; then compounds 4 and 3 (each within the scatter of the next).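

In this assay, replacing 3-chlorophenyl with 4-chlorophenyl on the oxygen gives a 12-fold higher number from compound 2 to compound 4 (1.09 log units; beyond the scatter), although the two compounds hold the same atoms, joined differently. Within the data shown here, no earlier pair isolated this change, so this is the first sign that the place of the chlorine on this phenyl ring matters. Nothing available explains the step.

Open, going by these compounds, is whether bromine or a methoxy group in place of the chlorine would show the same sensitivity. Also open, on these data alone, is whether the step would hold on the core of compound 3.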